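A Methoxy in Place of a Chloro

The source may hold more compounds than are shown below. What is called first, only, known or untested is meant among the compounds shown, and "the series" means these compounds.

Of the compounds shown here, three have been measured in a functional assay on DU-145 cells (Homo sapiens) for cytotoxicity, read by trypan blue exclusion, with a stated time of 96 h; on this read-out higher numbers stand for weaker inhibition and lower numbers for stronger inhibition. Compound 1 `COC(=O)C(Nc1cc(CS(=O)(=O)/C=C/c2c(OC)cc(OC)cc2OC)ccc1OC)c1ccccc1` gives 75 nM, and compound 2 `COc1cc(OC)c(/C=C/S(=O)(=O)Cc2ccc(OC)c(NC(C(=O)O)c3ccc(F)cc3)c2)c(OC)c1` gives 150 nM. Compound 3 `COc1cc(OC)c(/C=C/S(=O)(=O)Cc2ccc(OC)c(NC(C(=O)O)c3ccc(Cl)cc3)c2)c(OC)c1` gives 400 nM, the highest of the three numbers, which makes it the weakest inhibitor of the set. Compound 4 `COc1ccc(C(Nc2cc(CS(=O)(=O)/C=C/c3c(OC)cc(OC)cc3OC)ccc2OC)C(=O)O)cc1` has not yet been measured. It carries methoxy in place of chloro on an aromatic carbon, para to a large group, so that 4-chlorophenyl becomes 4-methoxyphenyl: methoxy in place of chloro on an aromatic carbon.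

The measured step closest to this change swaps fluoro for chloro at the same spot, and it is modest: a 2.7-fold higher number from compound 2 to compound 3 (0.43 log units; beyond the scatter). The other two steps also change the methoxycarbonyl side of the molecule. One lies within the scatter, a 2.0-fold higher number from compound 1 to compound 2 (0.30 log units; within the scatter), and the other is modest, a 5.3-fold higher number from compound 1 to compound 3 (0.73 log units; beyond the scatter). Going by the values given here, no measured compound carries methoxy at this spot, so the data offer no direct reading. Compound 3 sits at the top of the range, and compound 2 at 150 nM shows that a close relative can lie lower. A small shift toward a lower number is therefore expected, and the estimated change stays within the scatter: a 1.6-fold lower number from compound 3 to compound 4 (0.20 log units; within the scatter). For compound 4 the expected value is 250 nM, with an estimated range from 80 nM to 700 nM.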

Compound 4, half-maximal inhibitory concentration: 100 nM
Compound 4: the middle estimate sits 2.5-fold (0.40 log units) above what was measured; the measured number falls inside the stated range.
By their numbers in this assay, from the lowest: compounds 1, 4 and 2 (each within the scatter of the next); then compound 3.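

Going by these compounds alone, at this aromatic carbon, para to a large group, the earlier compounds had set chloro only against fluoro, and now a second group separates from it: in this assay, methoxy in place of chloro gives a 4.0-fold lower number from compound 3 to compound 4 (0.60 log units; beyond the scatter). Methoxy and fluoro cannot be told apart at this spot, with a 1.5-fold lower number from compound 2 to compound 4 (0.18 log units; within the scatter), and the step that also changes the methoxycarbonyl side stays within the scatter as well, with a 1.3-fold higher number from compound 1 to compound 4 (0.12 log units; within the scatter), so among the three compounds with a carboxy group, only the chloro compound, compound 3, stands apart. The data shown give no explanation for this difference.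

The compounds shown leave open whether an amine, a hydroxy group or a longer chain such as ethoxy at this carbon would stay level with compound 4 at 100 nM or move toward the value of compound 3 at 400 nM. They also leave open whether the 4-methoxyphenyl group would read the same beside a methoxycarbonyl group as it does beside the carboxylic acid of compound 4.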